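A few compounds are considered here, and "the series" means these few. Any claim that something is new, unique, unknown or untested is made for them only; others in the source may bear on it.

Compounds measured so far:
compound 1, `CSCc1ccc(Nc2ncc(Cc3c(F)cccc3F)o2)cc1`: > 100000 nM
compound 2, `Fc1cccc(F)c1Cc1cnc(Nc2ccc(-c3cccnc3)c(Cl)c2)o1`: 8900 nM

Of the compounds shown here, two have been tested in an ADME assay on MT2 cells (Homo sapiens) for cytotoxicity, read by MTT assay; on this read-out higher numbers stand for lower toxicity in this test and lower numbers for higher toxicity in this test. For compound 1 the result > 100000 nM is a limit of the assay and not a number. This places compound 1 at the limit of > 100000 nM in this assay, at which 1 of the 2 values shown sits, the less toxic end of what the test can report. Compound 2 gives 8900 nM in this assay, a value that is a measured number rather than a limit.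

Compound 3, `OCc1ccc(Nc2ncc(Cc3c(F)cccc3F)o2)cc1`, differs from compound 1 in one place: hydroxy in place of methylsulfanyl on a saturated chain carbon bound to an aromatic carbon. The rest of the molecule, including the shared core of compound 1, is unchanged. Going by the values given here, no pair of measured compounds that differ in a single place is available, so there is no measured step to lean on. For a change of this size, the step of a number no higher from compound 1 to compound 3 (the limit leaves the size open) is expected to be none beyond the usual scatter of the test. Compound 3 is therefore estimated at 100000 nM, within a range from 30000 nM to 300000 nM, and it is quite possible that the test will again report only a limit.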

Compound 3, half-maximal cytotoxic concentration: > 100000 nM
Compound 3 was reported as a limit; the forecaster's own chance of this, stated with the estimate: 65%; the middle value sits exactly at the limit.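

Compound 1 and compound 3 are both reported only as a limit in this assay, so no step can be read between them: the limit of > 100000 nM in this assay, at which 2 of the 3 values shown sit.

The compounds shown leave open how far apart the true values of compound 1 and compound 3 lie, and whether hydroxy in place of methylsulfanyl makes any difference in this assay.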